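Methoxy to hydroxy: from compound 1 to compound 3

The source may report more compounds than this note shows. Statements on the series, on what has been measured and on what is new or still open speak of the compounds shown alone.

Measured in a functional assay on MDA-MB-231 cells (Homo sapiens) for cytotoxicity, read by MTT assay, with a stated time of 72 h; a higher number here means a weaker inhibitor, a lower number a stronger inhibitor:
- compound 1 `COc1ccc(/C=C/c2cc(C)no2)cc1OC`: 79900 nM
- compound 2 `COc1ccc(/C=C/c2cc(C)no2)cc1`: 69300 nM

Within the data shown here, compound 1 has compound 2 as its only neighbour on the numbers, and the two lie within the scatter of each other, so compound 1 holds no distinct rank. Compound 3 `COc1cc(/C=C/c2cc(C)no2)ccc1O` is not yet measured. It differs from compound 1 at one place, methoxy to hydroxy: hydrogen in place of methyl on an oxygen on an aromatic ring. Among the measured compounds shown here, the only measured step is a 1.2-fold lower number from compound 1 to compound 2 (0.06 log units; within the scatter), with hydrogen in place of methoxy on an aromatic carbon. For the measured compounds named here, that is a different change, and no measured compound carries a hydroxy, so it bears only indirectly. On that limited evidence, no step beyond the scatter is expected in this assay. The estimated step is a 1.2-fold lower number from compound 1 to compound 3 (0.09 log units; within the scatter). For compound 3 the estimate is 65000 nM, with an expected range of 28000 nM to 120000 nM.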

Compound 3, half-maximal inhibitory concentration: 34600 nM
Compound 3: the middle estimate sits 1.9-fold (0.27 log units) above what was measured, and the stated range covers the measured number.
By their numbers in this assay, from the lowest: compounds 3, 2 and 1 (each within the scatter of the next, the first and the last beyond it).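

In this assay, among these compounds, a 2.3-fold lower number from compound 1 to compound 3 (0.36 log units; beyond the scatter) is the first step beyond the scatter, though a modest one. This change removes only the methyl and keeps the oxygen on the aromatic ring, whereas a 1.2-fold lower number from compound 1 to compound 2 (0.06 log units; within the scatter) replaces a whole methoxy and stays within the scatter. Nothing on hand explains the step, so the series records it without a cause.

Open, as far as these compounds go, is whether the step depends on the free hydroxy itself, which an amine at this place or a longer chain such as ethoxy on the same oxygen would test. Also open, from the compounds shown here alone, is whether hydroxy in place of the methoxy that compound 3 keeps would give a step of like size.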